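The source may hold more compounds than are shown below. What is called first, only, known or untested is meant among the compounds shown, and "the series" means these compounds.

Working notes on the series. In a functional assay on MCF7 cells (Homo sapiens) for antiproliferative activity, read by sulforhodamine B assay, with a stated time of 72 h (a higher number here means a weaker inhibitor, a lower number a stronger inhibitor), compound 1 `COc1cc(/C=C2\CCC=CC2=O)cc(OC)c1` gives 4620 nM and compound 2 `COc1cc(/C=C2\CCC=CC2=O)cc(OC)c1OC` gives 5260 nM. Within the data shown here, compound 2 thus stands within the scatter of compound 1, the only other measured compound, and the two numbers cannot be told apart.

The next compound is compound 3 `COc1cc(/C=C2\CCC=CC2=O)cc(OC)c1O`. It differs from compound 2 at one place: hydrogen in place of methyl on an oxygen on an aromatic ring, or methoxy to hydroxy.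

Among the measured compounds shown here, only one measured step bears on this, a 1.1-fold higher number from compound 1 to compound 2 (0.06 log units; within the scatter), for methoxy in place of hydrogen on an aromatic carbon. For the measured compounds named here, it is a different change from the one at hand, and no measured compound carries a hydroxy, so the guidance is weak. Going by a 1.1-fold higher number from compound 1 to compound 2 (0.06 log units; within the scatter), a step no larger than the scatter is expected in this assay, with no firm direction.

Compound 3 is estimated at 4500 nM, with an expected range of 1800 nM to 11000 nM. The expected change is a 1.2-fold lower number from compound 2 to compound 3 (0.07 log units; within the scatter).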

Compound 3, half-maximal inhibitory concentration: 2180 nM
Compound 3: middle estimate off by 2.1-fold (0.31 log units), on the high side; the measured number falls inside the stated range.
By their numbers in this assay, from the lowest: compound 3; then compounds 1 and 2 (each within the scatter of the next).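

In this assay, among these compounds, methoxy to hydroxy gives a 2.4-fold lower number from compound 2 to compound 3 (0.38 log units; beyond the scatter), the first step to lie beyond the scatter, though it remains modest. Compared with hydrogen on the same aromatic carbon, hydroxy gives a 2.1-fold lower number from compound 1 to compound 3 (0.33 log units; beyond the scatter), whereas methoxy there gave only a 1.1-fold higher number from compound 1 to compound 2 (0.06 log units; within the scatter), so among these three compounds only the hydroxy compound separates from the others, and methoxy and hydrogen cannot be told apart at this place. Nothing available explains this separation.

The compounds shown leave open whether the lower number is specific to hydroxy or would also appear with another group at this place, such as an amine, a fluorine or an ethoxy group. Among the compounds shown here, they also leave open whether the hydroxy step would keep its size if either of the two remaining methoxy groups were changed, or if the rest of the shared core were altered, as the series so far varies only this one place.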